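Moving the Halogen on the Aryl Triazole Group

The source may report more compounds than this note shows. Statements on the series, on what has been measured and on what is new or still open speak of the compounds shown alone.

Compound 1 `CC1(C)[C@H]2CC[C@]1(C)N(Cc1cn(-c3cccc(F)c3)nn1)C(=O)C2`: 430 nM
Compound 2 `CC1(C)[C@H]2CC[C@]1(C)N(Cc1cn(-c3ccccc3C#N)nn1)C(=O)C2`: 110 nM
Compound 3 `CC1(C)[C@H]2CC[C@]1(C)N(Cc1cn(-c3ccc(F)cc3)nn1)C(=O)C2`: 200 nM

All three values come from a functional assay on OVCAR-3 cells (Homo sapiens) for inhibition, read by MTT assay, with a stated time of 24 h; on this read-out lower numbers stand for stronger inhibition and higher numbers for weaker inhibition. Compound 3 holds the middle place at 200 nM: the gap in a 1.8-fold higher number from compound 2 to compound 3 (0.26 log units; within the scatter) stays within the scatter, whereas a 2.2-fold lower number from compound 1 to compound 3 (0.33 log units; beyond the scatter) lies beyond it. Compound 4 `CC1(C)[C@H]2CC[C@]1(C)N(Cc1cn(-c3cccc(Cl)c3)nn1)C(=O)C2` carries 3-chlorophenyl in place of 4-fluorophenyl on an aromatic nitrogen. Going by the values given here, no chlorinated compound has been measured, so the nearest guide is the 3-fluorophenyl group of compound 1 at 430 nM. Read in reverse, a 2.2-fold lower number from compound 1 to compound 3 (0.33 log units; beyond the scatter) points to a modest move towards a higher number in this assay. The expected step is a 2.1-fold higher number from compound 3 to compound 4 (0.32 log units; beyond the scatter). For compound 4 the estimated value is 420 nM, with an expected range of 160 nM to 1000 nM.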

Compound 4, half-maximal inhibitory concentration: 50 nM
Beside the measured number, compound 4's estimate is 8.4-fold (0.92 log units) above it; the whole stated range lies above it.
By their numbers in this assay, from the lowest: compound 4; then compounds 2 and 3 (each within the scatter of the next); then compound 1.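

In this assay, 3-chlorophenyl on the aromatic nitrogen gives the lowest number of the set, with a 4.0-fold lower number from compound 3 to compound 4 (0.60 log units; beyond the scatter) and a 2.2-fold lower number from compound 2 to compound 4 (0.34 log units; beyond the scatter). Chloro in place of fluoro on the same aromatic carbon gives an 8.6-fold lower number from compound 1 to compound 4 (0.93 log units; beyond the scatter). The earlier compounds had shown only a shift in where fluoro sits and a change to 2-cyanophenyl, whereas this step shows that the identity of the halogen also matters on this aryl group. Nothing available explains this result. The compounds shown leave open how 3-bromophenyl, 3-methoxyphenyl or 4-chlorophenyl would compare.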